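The source may report more compounds than this note shows. Statements on the series, on what has been measured and on what is new or still open speak of the compounds shown alone.

Values in a functional assay on HeLa cells (Homo sapiens) for inhibition, read by MTT assay, with a stated time of 48 h; on this read-out higher numbers stand for weaker inhibition and lower numbers for stronger inhibition:
- Compound 1 `COc1ccc(-c2nc3ccccn3c2Sc2ccccc2)cc1`: > 100000 nM
- Compound 2 `C(=C/c1nc2ccccn2c1Sc1ccccc1)\c1ccccc1`: 35500 nM
- Compound 3 `CSc1ccc(-c2nc3ccccn3c2Sc2ccccc2)cc1`: 30000 nM

The entry for compound 1 is a limit of the assay and not a number. Compound 3, at 30000 nM, has only compound 2 as a numerical neighbour, and the two stand level: the change is a 1.2-fold lower number from compound 2 to compound 3 (0.07 log units; within the scatter).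

Compound 4 `c1ccc(Sc2c(-c3ccsc3)nc3ccccn23)cc1` keeps the shared core and the phenylsulfanyl group, but carries thiophen-3-yl in place of 4-(methylsulfanyl)phenyl on an aromatic carbon.

Within the data shown here, all the measured steps concern this same place. Methylsulfanyl in place of methoxy gave an at least 3.3-fold lower number from compound 1 to compound 3 (0.52 log units; beyond the scatter), and 2-phenylethenyl in place of 4-methoxyphenyl gave an at least 2.8-fold lower number from compound 1 to compound 2 (0.44 log units; beyond the scatter). Both are at least modest, so the group here can matter. Even so, the closest guide is the swap between two quite different groups that gave a 1.2-fold lower number from compound 2 to compound 3 (0.07 log units; within the scatter). Among the measured compounds shown here, no measured compound carries thiophen-3-yl, so the direction stays uncertain, and no step beyond the scatter is expected in this assay. The expected step is a 1.3-fold higher number from compound 3 to compound 4 (0.12 log units; within the scatter). For compound 4 the estimated value is 40000 nM, with an expected range of 15000 nM to 100000 nM.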

Compound 4, half-maximal inhibitory concentration: 76000 nM
Compound 4: the middle estimate sits 1.9-fold (0.28 log units) below what was measured, within the range that was stated.
By their numbers in this assay, from the lowest: compounds 3 and 2 (each within the scatter of the next); then compound 4. At a limit, above all of these: compound 1.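

In this assay, among these compounds, thiophen-3-yl is the first group at this position that clearly separates from both groups with a numerical value: the change gives a 2.5-fold higher number from compound 3 to compound 4 (0.40 log units; beyond the scatter), and it gives a 2.1-fold higher number from compound 2 to compound 4 (0.33 log units; beyond the scatter). Compounds 2 and 3 had stood level despite their different groups, whereas this result shows that the position can distinguish between groups, with a five-membered aromatic ring of 5 heavy atoms giving weaker inhibition here than either of those larger groups. Against the remaining entry, the change gives an at least 1.3-fold lower number from compound 1 to compound 4 (0.11 log units; that floor lies within the scatter), and this floor cannot separate the two groups. The entry for compound 1 is a limit of the assay and not a number: the limit of > 100000 nM in this assay, at which 1 of the 4 values shown sits.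

These compounds do not separate the effect of the smaller ring from the loss of the methylsulfanyl group, and a plain phenyl or a furan-3-yl group at this carbon would help to pull the two apart. Also open, going by these compounds, is how an amine or a carboxylic acid on the ring at this position would behave, and how much the phenylsulfanyl group, unchanged throughout, contributes.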